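Working notes: replacing pyrimidin-4-yl on the amine nitrogen

The source may report more compounds than this note shows. Statements on the series, on what has been measured and on what is new or still open speak of the compounds shown alone.

In an ADME assay on microsomes from liver (Homo sapiens) for metabolic stability, read by LC-MS (on this read-out higher numbers stand for fast clearance and lower numbers for slow clearance), compound 1 (`FC(F)(F)c1nccc(N[C@H]2CC[C@@H](Nc3ncnc4sccc34)CC2)n1`) gives 22 mL.min-1.g-1, compound 2 (`FC(F)(F)c1nccc(N[C@@H]2CC[C@H](Nc3ccc4nnc(Cl)n4n3)C2)n1`) gives 17 mL.min-1.g-1 and compound 3 (`Clc1nnc2ccc(N[C@H]3CC[C@@H](Nc4ccncn4)CC3)nn12`) gives 25 mL.min-1.g-1. Compound 3 lies within the scatter of both compound 1 and compound 2, so these three values cannot be separated.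

Compound 4 (`COc1ncc(N[C@H]2CC[C@@H](Nc3ccc4nnc(Cl)n4n3)CC2)cc1Cl`) follows from compound 3, with 5-chloro-6-methoxypyridin-3-yl in place of pyrimidin-4-yl on an amine nitrogen. Among the compounds with values here, no measured pair isolates a single change, so the data give no direct guide to the size of this step. Starting from compound 3 at 25 mL.min-1.g-1, a modest move towards faster clearance in this assay is expected, not clearly beyond the scatter, though a larger move cannot be excluded. The estimated step is a 1.6-fold higher number from compound 3 to compound 4 (0.20 log units; within the scatter). For compound 4 the expected value is 40 mL.min-1.g-1, with an estimated range from 18 mL.min-1.g-1 to 85 mL.min-1.g-1.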

Compound 4, intrinsic clearance in microsomes in the Homo sapiens assay: < 3 mL.min-1.g-1
Compound 4 was reported as a limit; the forecaster's own chance of this, stated with the estimate: 3%; middle value at least 13-fold (1.12 log units) from the limit.
By their numbers in the Homo sapiens assay, from the lowest: compounds 2, 1 and 3 (each within the scatter of the next). At a limit, below all of these: compound 4.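

In the Homo sapiens assay the group on this amine nitrogen matters: replacing pyrimidin-4-yl with 5-chloro-6-methoxypyridin-3-yl gives an at least 8.3-fold lower number from compound 3 to compound 4 (0.92 log units; beyond the scatter), whereas compounds 1, 2 and 3 could not be separated. The value of compound 4 is a limit and not a number, so the size of this step has only a bound: the limit of < 3 mL.min-1.g-1 in the Homo sapiens assay, at which 1 of the 4 values shown sits. In a physicochemical assay for lipophilicity, read by LC-MS (a higher number here means a more lipophilic compound, a lower number a more polar compound), compound 3 gives 0.7 and compound 4 gives 3.8. In the physicochemical assay the same change gives a number 3.10 log units higher from compound 3 to compound 4 (beyond the scatter), so the slower clearance comes with a far more lipophilic compound: the measured distribution coefficient of compound 3, 0.7, and of compound 4, 3.8, a number 3.10 log units higher (beyond the scatter).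

The entering group differs from pyrimidin-4-yl in its ring, its chlorine and its methoxy all at once, so the compounds shown do not say which of these carries the step. Also open, from the compounds shown here alone, is whether a morpholine or an amide on the same pyridine ring would keep clearance this low at a lower distribution coefficient.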